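This account rests on a few compounds, and the source may have more. Where it says the series, first, only, none or still open, it means among the compounds named here.

Compound 1 `CCCCCCCCO[C@@H]1O[C@@H](C)[C@H](OC(=O)CCCCC)[C@@H](O[C@@H]2O[C@@H](C)[C@H](OC(C)=O)[C@@H](O[C@@H]3O[C@@H](C)[C@H](O)[C@@H](O)[C@H]3OC(C)=O)[C@H]2OC(C)=O)[C@H]1O` has been tested in a functional assay on Col2 cells (Homo sapiens) for cytotoxicity (on this read-out lower numbers stand for an effect already at smaller amounts and higher numbers for an effect only at larger amounts of compound), and gives 8.2 ug/mL. Compound 2 `CCCCCCCCO[C@@H]1O[C@@H](C)[C@H](OC(=O)CCCCC)[C@@H](O[C@@H]2O[C@@H](C)[C@H](OC(C)=O)[C@@H](O)[C@H]2OC(C)=O)[C@H]1O` is a shorter relative of compound 1. In this assay compound 2 gives only > 20 ug/mL, which is a limit of the assay rather than a number, so compound 2 sits at the limit of > 20 ug/mL in this assay, at which 1 of the 2 values shown sits. Compound 3 `CCCCCCCCO[C@@H]1O[C@@H](C)[C@H](OC(=O)CCCCC)[C@@H](O[C@@H]2O[C@@H](C)[C@H](OC(C)=O)[C@@H](OC(C)=O)[C@H]2OC(C)=O)[C@H]1O` differs from compound 2 by acetyl in place of hydrogen on an oxygen on a saturated carbon. Within the data shown here, no measured step of this kind is available, so the expected step is a number no higher from compound 2 to compound 3 (the limit leaves the size open), within the scatter of this assay. Compound 3 is therefore estimated to give about 20 ug/mL, between 10 ug/mL and 40 ug/mL.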

Compound 3, concentration for half-maximal effect: 9 ug/mL
Estimate against measurement, compound 3: 2.2-fold (0.35 log units) above, outside the stated range (below it).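

In this assay, placing acetyl on this hydroxy oxygen gives an at least 2.2-fold lower number from compound 2 to compound 3 (0.34 log units; beyond the scatter), so this position responds to a small change. From the compounds shown here alone, compound 2 gives > 20 ug/mL, which is a limit of the assay, so the full size of the step stays open: the limit of > 20 ug/mL in this assay, at which 1 of the 3 values shown sits. Compound 1, with a larger group on this same oxygen, gives 8.2 ug/mL, and compound 3 gives 9 ug/mL, so these two values lie close together. The compounds shown leave open whether acetyl itself matters. An amine or a longer acyl chain such as octanoyl on this oxygen could answer that.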